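The compounds below may be only part of what the source reports. "The series", "measured", "known", "first", "only" and "open" are said of these compounds alone.

Compounds measured so far:
- compound 1, `Cc1ccc(NC(=O)CCCCc2cn(Cc3ccc4oc(-c5ccc(Cl)cc5)cc(=O)c4c3)nn2)cc1`: 32900 nM
- compound 2, `Cc1ccc(NC(=O)CCCCc2cn(Cc3ccc4oc(-c5ccccc5)cc(=O)c4c3)nn2)cc1`: 15600 nM

Both numbers come from an assay on isolated protein for inhibition of Amine oxidase [flavin-containing] B (Homo sapiens), read by fluorescence and spectrophotometry; a higher number here means a weaker inhibitor, a lower number a stronger inhibitor. Compound 1 gives the higher of the two numbers, so it is the weaker inhibitor of the pair; its nearest neighbour is compound 2, reached by a 2.1-fold lower number from compound 1 to compound 2 (0.32 log units; beyond the scatter), where the change is hydrogen in place of chloro on an aromatic carbon.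

Compound 3, `O=C(CCc1cn(Cc2ccc3oc(-c4ccc(Cl)cc4)cc(=O)c3c2)nn1)Nc1ccccc1`, has not yet been measured. Relative to compound 1 the change is a group of 9 heavy atoms (7 carbon, 1 nitrogen, 1 oxygen; one six-membered aromatic ring of carbon only) in place of a group of 12 heavy atoms (10 carbon, 1 nitrogen, 1 oxygen; one six-membered aromatic ring of carbon only), on a saturated chain carbon, two bonds along the chain from an aromatic carbon; in words, a group of 9 heavy atoms (7 carbon, 1 nitrogen, 1 oxygen; one six-membered aromatic ring of carbon only) in place of a group of 12 heavy atoms (10 carbon, 1 nitrogen, 1 oxygen; one six-membered aromatic ring of carbon only), on a saturated chain carbon, two bonds along the chain from an aromatic carbon. Among the compounds with values here, the only measured step, from compound 1 to compound 2, alters a different part of the molecule, so no measured step bears on this change. With nothing to indicate a direction, the number for compound 3 is expected to stay near that of compound 1, and the step from compound 1 to compound 3 is estimated at a 1.1-fold lower number from compound 1 to compound 3 (0.04 log units; within the scatter), with wide uncertainty. In this assay compound 3 is estimated at 30000 nM, between 8000 nM and 120000 nM.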

Compound 3, half-maximal inhibitory concentration: 32900 nM
Compound 3: middle estimate off by 1.1-fold (0.04 log units), on the low side; the measured number falls inside the stated range.
By their numbers in this assay, from the lowest: compound 2; then compounds 1 and 3 (each within the scatter of the next).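

Within the data shown here, until now the only measured change lay in a different part of the molecule, at the chloro group, so this is the first reading on the saturated chain carbon, two bonds along the chain from an aromatic carbon. In this assay, putting phenylcarbamoyl in place of the larger group of 12 heavy atoms gives no change at the digits printed from compound 1 to compound 3 (within the scatter), so this position accepts the smaller group with no detectable loss or gain, even though the swap both shortens the chain and removes the methyl group from the ring. Nothing available explains why the number holds steady, and a flat result of this kind could equally reflect a single indifferent region or two separate edits that offset each other.

The chain length and the methyl group change together here, so the compounds shown cannot separate their contributions, and a compound changing only one of them would be needed to do that. Also open, as far as these compounds go, is whether a quite different group at this position, such as an amine or a carboxylic acid in place of the phenyl amide, would move the number at all.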